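Growing the Alkyl Group on an Aromatic Nitrogen

This account rests on a few compounds, and the source may have more. Where it says the series, first, only, none or still open, it means among the compounds named here.

Compound 1 `Cn1c(/C=C2\SC(=O)N(CC(=O)N3CCOCC3)C2=O)nc2ccccc21` is the reference point of this small set. In a functional assay on DU-145 cells (Homo sapiens) for inhibition, read by MTT assay, with a stated time of 48 h (a higher number here means a weaker inhibitor, a lower number a stronger inhibitor), compound 1 gives 41100 nM. Compound 3 `CCn1c(/C=C2\SC(=O)N(CC(=O)N3CCOCC3)C2=O)nc2ccccc21` differs from it by methyl in place of hydrogen on a saturated chain carbon bound to an aromatic nitrogen. In this assay compound 3 reaches only the limit of the assay, > 50000 nM, which is not a number. That pairing yields an at least 1.2-fold higher number from compound 1 to compound 3 (0.08 log units; that floor lies within the scatter), and the reading rests on (the limit of > 50000 nM in this assay, at which 2 of the 3 values shown sit).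

Compound 2 `CCn1c(/C=C2\SC(=O)N(CC(=O)N3CCc4cc(OC)c(OC)cc4C3)C2=O)nc2ccccc21` is built on a different core; the difference between the two cores is not broken down here. In this assay compound 2 also stands at the limit, > 50000 nM, again not a number.

Compound 4 `COc1cc2c(cc1OC)CN(C(=O)CN1C(=O)S/C(=C\c3nc4ccccc4n3C(C)C)C1=O)CC2` has not been measured. It differs from compound 2 by methyl in place of hydrogen on a saturated chain carbon bound to an aromatic nitrogen and a saturated chain carbon. Going by the values given here, this is the same kind of change as the one from compound 1 to compound 3, although here the carbon gaining the methyl is also bound to a saturated chain carbon.

Because the earlier step of an at least 1.2-fold higher number from compound 1 to compound 3 (0.08 log units; that floor lies within the scatter) ran toward weaker inhibition, compound 4 is expected to show a step that the limit leaves unreadable from compound 2 to compound 4. Compound 4 is therefore estimated at 60000 nM, between 25000 nM and 150000 nM.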

Compound 4, half-maximal inhibitory concentration: 29700 nM
For compound 4 the middle estimate is 2.0-fold (0.31 log units) above the measured one; the measured number falls inside the stated range.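

Compound 2 stands at a limit of the assay, > 50000 nM, which is not a number. In this assay, from the compounds shown here alone, the change from ethyl to isopropyl on this core can therefore be read only as a floor, an at least 1.6-fold lower number from compound 2 to compound 4 (0.22 log units; that floor lies within the scatter), so the true size of the step remains unknown. This does not show that the change acts differently on the two cores, nor that it acts alike on them, since both steps are known only as floors: the same change on two cores in this assay, an at least 1.2-fold higher number (0.08 log units; that floor lies within the scatter) from compound 1 to compound 3 and an at least 1.6-fold lower number (0.22 log units; that floor lies within the scatter) from compound 2 to compound 4; the limit leaves it open whether they differ.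

The compounds shown leave open what a longer chain such as n-butyl, or a benzyl group, would do on the same aromatic nitrogen of either core. They also leave open how isopropyl would behave on the core of compound 1, and the limit still hides the size of both steps: the limit of > 50000 nM in this assay, at which 2 of the 4 values shown sit.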